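Methylamino for methoxy: expected outcome for compound 3

The source may hold more compounds than are shown below. What is called first, only, known or untested is meant among the compounds shown, and "the series" means these compounds.

Compound 1, `Nc1nc(Cl)c(-c2nc3ccc(F)cc3s2)c(N[C@@H]2C[C@H](CO)[C@@H](O)[C@H]2O)n1`, and compound 2, `COc1ccc2nc(-c3c(Cl)nc(N)nc3N[C@@H]3C[C@H](CO)[C@@H](O)[C@H]3O)sc2c1`, share one core and differ at a single aromatic carbon. In an ADME assay on cells (Homo sapiens) for cytotoxicity, read by polymerase chain reaction, with a stated time of 3 days (on this read-out higher numbers stand for lower toxicity in this test and lower numbers for higher toxicity in this test), compound 1 gives > 25000 nM, a limit of the assay and not a number. In this assay compound 2 gives > 25000 nM, likewise a limit rather than a number. The step that the two limits leave unreadable from compound 1 to compound 2, methoxy in place of fluoro on an aromatic carbon, has no readable size; the shared position of the two values is summarised by the limit of > 25000 nM in this assay, at which 2 of the 2 values shown sit. Compound 2 thus stands only at a limit, with no number to set against compound 1.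

Compound 3, `CNc1ccc2nc(-c3c(Cl)nc(N)nc3N[C@@H]3C[C@H](CO)[C@@H](O)[C@H]3O)sc2c1`, is to be measured in this assay. It differs from compound 2 by methylamino in place of methoxy on an aromatic carbon. Within the data shown here, the only measured step at this aromatic carbon, from compound 1 to compound 2, was unreadable, so no size of step can be carried forward. With compound 2 showing only a limit, compound 3 is expected to remain at or beyond that limit, an expected step that the limit leaves unreadable from compound 2 to compound 3. Compound 3 is estimated at 40000 nM, with a range from 20000 nM to 100000 nM.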

Compound 3, half-maximal cytotoxic concentration: 6000 nM
The estimate for compound 3 lay 6.7-fold (0.82 log units) above the measured number; the measured number lies below the stated range.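

Among these compounds, until this result the position offered only limits of the assay in this assay, and the step between those two limits cannot be read: the limit of > 25000 nM in this assay, at which 2 of the 3 values shown sit. Methylamino in place of methoxy now gives an at least 4.1-fold lower number from compound 2 to compound 3 (0.61 log units; beyond the scatter), and methylamino in place of fluoro gives an at least 4.1-fold lower number from compound 1 to compound 3 (0.61 log units; beyond the scatter), so this aromatic carbon is shown to be able to move the read-out toward higher toxicity in this test, even through an exchange of one group of 2 heavy atoms for another. The count under this change is small: oxygen gives way to nitrogen and the entering group carries 1 hydrogen-bond donor where methoxy carries 0, while the rest of the structure stays the same.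

From the compounds shown here alone, the true size of both steps stays open, since each starts from a limit, and the three compounds cannot tell whether the nitrogen or its hydrogen goes with the lower number. Dimethylamino, which keeps the nitrogen without that hydrogen, and an unsubstituted amine at the same carbon would separate these two readings.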